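Swapping a 2-fluorobenzyl for a tert-butyl on a shared core

The source may hold more compounds than are shown below. What is called first, only, known or untested is meant among the compounds shown, and "the series" means these compounds.

This account concerns two measured compounds and one untested analogue of a shared core. Compound 1 `CCCCc1cnc(CCCc2ccc(-c3ccccc3C(=O)O)cc2)[nH]1` and compound 2 `O=C(O)c1ccccc1-c1ccc(CCc2ncc(Cc3ccccc3F)[nH]2)cc1` were both tested in an in vitro functional assay on cells for agonist activity at Bombesin receptor subtype-3 (Mus musculus), read by luminescence and calcium flux; on this read-out higher numbers stand for an effect only at larger amounts of compound and lower numbers for an effect already at smaller amounts. In this assay compound 1 gives 382 nM, while compound 2 gives 9.5 nM. Compound 2 thus stands at the lowest of the two numbers, and the gap between it and compound 1 lies well beyond the usual scatter of repeated measurements. Going by the values given here, the two compounds differ in more than one place, so no single structural step between them is counted here; only their two values can be set side by side.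

Compound 3 `CC(C)(C)c1cnc(CCc2ccc(-c3ccccc3C(=O)O)cc2)[nH]1` is the untested analogue. It differs from compound 2 in one place: tert-butyl in place of 2-fluorobenzyl on an aromatic carbon. Among the compounds with values here, a tert-butyl is a smaller group than the 2-fluorobenzyl it replaces, and the only measured compound that carries a group without a ring at that position, compound 1, sits far from compound 2. On that basis a step upward, beyond the scatter, is expected in this assay, with the size a 16-fold higher number from compound 2 to compound 3 (1.20 log units; beyond the scatter) estimated for the change from compound 2 to compound 3. Compound 3 is therefore expected to give about 150 nM, within a range from 40 nM to 600 nM.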

Compound 3, half-maximal effective concentration: 2750 nM
Compound 3: the middle estimate sits 18-fold (1.26 log units) below what was measured; the whole stated range lies below it.
By their numbers in this assay, from the lowest: compound 2; then compound 1; then compound 3.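

In this assay, the exchange of 2-fluorobenzyl for tert-butyl gives a 290-fold higher number from compound 2 to compound 3 (2.46 log units; beyond the scatter), a large step that lies beyond the scatter and shows that the group on this aromatic carbon of the five-membered ring weighs heavily on the shared core. Going by these compounds alone, until now, only two compounds differing in more than one place could be set side by side, so no change in the read-out could be tied to this position alone; this pair isolates it. The group that leaves carries one six-membered aromatic ring of carbon only and the group that enters has no ring, while both count no hydrogen-bond donors or acceptors and no net charge, so the counted difference here lies in the ring and the number of heavy atoms.

The compounds shown leave open whether a plain benzyl without the fluorine, a cyclohexylmethyl or a phenyl at this place would keep a number near that of compound 2 at 9.5 nM, and so whether the ring, the fluorine or the linking carbon counts most. Nothing given here accounts for the size of this step.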